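Bromo in Place of Methoxy on the Amide Aryl Group

A few compounds are considered here, and "the series" means these few. Any claim that something is new, unique, unknown or untested is made for them only; others in the source may bear on it.

Measured compounds in an in vivo ADME assay on the whole organism (strain Sprague-Dawley) for metabolic stability, with Rattus norvegicus as the target; on this read-out higher numbers stand for a longer-lived compound and lower numbers for a shorter-lived compound:
compound 1, `COc1ncc(C(=O)NC2(C(=O)N[C@H](C)c3ccc(-n4nc(Cl)c5ccccc54)cc3F)CC2)s1`: compound 1 gives 8.3 h
compound 2, `C[C@@H](NC(=O)C1(NC(=O)c2cncc(Cl)n2)CC1)c1ccc(-n2nc(Cl)c3ccccc32)cc1F`: compound 2 gives 1.6 h
compound 3, `COc1cncc(C(=O)NC2(C(=O)N[C@H](C)c3ccc(-n4nc(Cl)c5ccccc54)cc3F)CC2)c1`: compound 3 gives 0.7 h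

Compound 3 has the lowest number of the three: a 12-fold lower number from compound 1 to compound 3 (1.07 log units; beyond the scatter) and a 2.3-fold lower number from compound 2 to compound 3 (0.36 log units; beyond the scatter). Compound 4, `C[C@@H](NC(=O)C1(NC(=O)c2cncc(Br)c2)CC1)c1ccc(-n2nc(Cl)c3ccccc32)cc1F`, differs from compound 3 by bromo in place of methoxy on an aromatic carbon. Every measured step exchanged the whole aryl group on the carbonyl carbon, so none of them bears directly on replacing a methoxy with a bromo at one position; those steps ran from modest to large in this assay. Among the compounds with values here, with no direct precedent, the expectation is a step within the scatter, a 1.7-fold higher number from compound 3 to compound 4 (0.23 log units; within the scatter). Compound 4 is therefore estimated at 1.2 h, with a range from 0.5 h to 3 h.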

Compound 4, half-life: 3.1 h
Beside the measured number, compound 4's estimate is 2.6-fold (0.41 log units) below it, outside the stated range (above it).
By their numbers in this assay, from the lowest: compound 3; then compounds 2 and 4 (each within the scatter of the next); then compound 1.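

On the pyridine ring, exchanging methoxy for bromo is enough on its own to shift this assay, giving a 4.4-fold higher number from compound 3 to compound 4 (0.65 log units; beyond the scatter), so this position matters even when the rest of the aryl group stays the same. Against the other aryl groups, the new 5-bromopyridin-3-yl group gives a 1.9-fold higher number from compound 2 to compound 4 (0.29 log units; within the scatter) and a 2.7-fold lower number from compound 1 to compound 4 (0.43 log units; beyond the scatter), leaving compound 1 still the longest-lived of the set. Nothing available explains these steps. Going by these compounds, whether a chloro, a methyl or a nitrile at this place would behave like bromo remains open, as does whether replacing methoxy with bromo on the thiazole of compound 1 would have any similar effect.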